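The source may hold more compounds than are shown below. What is called first, only, known or untested is meant among the compounds shown, and "the series" means these compounds.

Going by the values given here, compound 1 `CN(C)CCCn1c(=O)n(C2OC(CO)[C@@H](O)[C@H]2O)c2nc(N)nc(O)c21` was tested in a functional assay (B cells) with Mus musculus as the target (a higher number here means that more compound is needed for the effect, a lower number that less compound is needed), and gives 194 uM, the highest of the two numbers measured so far. Among the compounds with values here, compound 2 `C=CCn1c(=O)n(CCCC)c2nc(N)nc(O)c21` gives 2 uM in this assay, a far lower number; the two structures differ in more than one place, so no single step connects them. Compound 3 `Nc1nc(O)c2c(n1)n(C1OC(CO)[C@@H](O)[C@H]1O)c(=O)n2Cc1ccc([N+](=O)[O-])cc1` has not yet been measured. It differs from compound 1 in one place: 4-nitrophenyl in place of 2-(dimethylamino)ethyl on a saturated chain carbon bound to an aromatic nitrogen. For this change a step of moderate size toward a lower number is expected, a 3.2-fold lower number from compound 1 to compound 3 (0.51 log units; beyond the scatter). Compound 3 is therefore estimated at 60 uM, within a range from 10 uM to 300 uM.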

Compound 3, concentration for half-maximal effect: 40 uM
Beside the measured number, compound 3's estimate is 1.5-fold (0.18 log units) above it; the range from low to high includes it.
By their numbers in this assay, from the lowest: compound 2; then compound 3; then compound 1.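

Replacing 2-(dimethylamino)ethyl with 4-nitrophenyl on a saturated chain carbon bound to an aromatic nitrogen gives a 4.9-fold lower number from compound 1 to compound 3 (0.69 log units; beyond the scatter) in this assay. Going by these compounds alone, this is the only single change that can be read here, and it shows that the number responds to what this position carries, even with the rest of the molecule unchanged. Nothing measured here explains the shift.

The step removes a dimethylamino group and adds both a benzene ring and a nitro group, so the compounds shown cannot say which of these changes matters. An unsubstituted benzyl group or a 4-aminobenzyl group at this position would help separate them.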